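This account rests on a few compounds, and the source may have more. Where it says the series, first, only, none or still open, it means among the compounds named here.

Compound 1, `COc1ccc([C@H]2CC(=O)N(C(C)=O)C2)cc1OC1CCCC1`. In a functional assay on HEK293 cells (Homo sapiens) for cytotoxicity (a higher number here means that more compound is tolerated, a lower number that less compound is tolerated), compound 1 gives > 10000 nM, which is a limit of the assay and not a number.
Compound 2, `COc1ccc([C@H]2CC(=O)N(c3ccccc3C#N)C2)cc1OC1CCCC1`. In this assay compound 2 gives > 10000 nM, again a limit.

Within the data shown here, compound 1 therefore stands at a limit, and the only other value shown is a limit as well: both sit at the limit of > 10000 nM in this assay, at which 2 of the 2 values shown sit. The step that the two limits leave unreadable from compound 1 to compound 2 is accordingly unreadable, although it exchanges acetyl for 2-cyanophenyl on the same amide-type nitrogen in a ring.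

Compound 3, `COc1ccc([C@H]2CC(=O)N(c3ccccc3C(F)(F)F)C2)cc1OC1CCCC1`, differs from compound 1 by 2-(trifluoromethyl)phenyl in place of acetyl on an amide-type nitrogen in a ring. Among the measured compounds shown here, the single measured step that bears on this change is the one from compound 1 to compound 2, and its size cannot be read. No step beyond the scatter can be foreseen in this assay from these data.

Compound 3 is expected to sit at the limit as well, estimated at 15000 nM, with a range from 7000 nM to 40000 nM. This estimate means an expected step that the limit leaves unreadable from compound 1 to compound 3.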

Compound 3, half-maximal cytotoxic concentration: > 10000 nM
Compound 3 was reported as a limit; the forecaster's own chance of this, stated with the estimate: 85%; the middle value is on the limit's open side.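

In this assay compound 3 gives > 10000 nM, again a limit. The steps to compound 3 from compound 1 and compound 2 therefore cannot be read: the limit of > 10000 nM in this assay, at which 3 of the 3 values shown sit. The compounds shown leave open whether the groups on the amide-type nitrogen differ at all in this assay.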